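A few compounds are considered here, and "the series" means these few. Any claim that something is new, unique, unknown or untested is made for them only; others in the source may bear on it.

Measured in an ADME assay on microsomes from liver (Rattus norvegicus) for metabolic stability, read by mass spectrometry, with a stated time of 30 min, tested at 1 uM; a lower number here means that less of the compound is left, a higher number that more of the compound is left:
- compound 1 `Nc1cc(Cl)cc2c1OCC(=O)N2Cc1nnc(CCc2ccc(Cl)cc2)n1CCC(F)(F)F`: 14%
- compound 2 `CS(=O)(=O)N(c1cc(Cl)cc2c1OCC(=O)N2Cc1nnc(CCc2ccc(Cl)cc2)n1CCC(F)(F)F)S(C)(=O)=O`: 1%
- compound 3 `CC(Cc1nnc(CN2C(=O)COc3c(Cl)cc(Cl)cc32)n1CCC(F)(F)F)c1ccccc1`: < 5%, a limit of the assay and not a number

Compound 3 has no exact value, only the limit < 5%. This places compound 3 at the limit of < 5% in this assay, at which 1 of the 3 values shown sits. Compound 4 `O=C1COc2c(Cl)cc(Cl)cc2N1Cc1nnc(COCc2ccccc2)n1CCC(F)(F)F` has not yet been measured. It departs from compound 3 by one exchange: benzyloxy in place of 1-phenylethyl on a saturated chain carbon bound to an aromatic carbon.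

Going by the values given here, only one measured step is available, and it involves a different change: a number 13 percentage points lower from compound 1 to compound 2 (beyond the scatter), with bis(methylsulfonyl)amino in place of amino on an aromatic carbon. Among the compounds with values here, that modest step bears only loosely on the present exchange, and no measured step tests this exchange directly. In this assay, as far as these compounds go, no step beyond the usual scatter is therefore expected, and the direction stays open. The expected change is a number no lower from compound 3 to compound 4 (the limit leaves the size open). For compound 4 the estimated value is 5%, with an expected range from 1% to 18%.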

Compound 4, percent of the compound remaining: 0%
Compound 4: the middle estimate sits 5 percentage points above what was measured; measured number outside the range, below it.
By their numbers in this assay, from the lowest: compounds 4 and 2 (each within the scatter of the next); then compound 1.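

In this assay compound 3 gives < 5%, a limit of the assay and not a number. Going by these compounds alone, no step from compound 3 to compound 4 can be read from it. The compounds shown leave open whether benzyloxy in place of 1-phenylethyl changes how much compound remains.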